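The source may report more compounds than this note shows. Statements on the series, on what has been measured and on what is new or still open speak of the compounds shown alone.

Compound 1 `O=C(COc1ccc(CNC2CC=C(c3c[nH]c4cccc(F)c34)CC2)c(F)c1)NO`: 915 nM
Compound 2 `Cc1[nH]c2ccccc2c1C1=CCC(NCc2ccc(OCC(=O)NO)cc2)CC1`: 898 nM
Compound 3 `Cc1[nH]c2cccc(F)c2c1C1=CCC(NCc2ccc(OCC(=O)NO)cc2F)CC1`: 1180 nM

In a functional assay on MCF7 cells (Homo sapiens) for antiproliferative activity, with a stated time of 72 h (on this read-out lower numbers stand for stronger inhibition and higher numbers for weaker inhibition), these three compounds sit close together. Compound 3, at 1180 nM, lies within the usual scatter of both compound 1 and compound 2, so the numbers do not separate it from either.

The next compound to consider is compound 4 `Cc1[nH]c2ccccc2c1C1=CCC(NCc2ccc(OCC(=O)NO)cc2F)CC1`. It differs from compound 3 in one place: hydrogen in place of fluoro on an aromatic carbon. In words, this is hydrogen in place of fluoro on an aromatic carbon of a six-membered aromatic ring of carbon only, part of a fused or bridged system of two rings.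

For the measured compounds named here, no measured step shows this exact swap. Going by the values given here, the only single-place step available is a different one, methyl in place of hydrogen on an aromatic carbon, and it gave a 1.3-fold higher number from compound 1 to compound 3 (0.11 log units; within the scatter). That is weak, indirect evidence, but it gives no reason to expect a large move from a single small change on this ring. The close values of compound 2 and compound 3 also fit a narrow spread in this small set.

The expected result is therefore no shift beyond the scatter in this assay, with an estimated 1.2-fold lower number from compound 3 to compound 4 (0.09 log units; within the scatter). For compound 4 the estimated value is 950 nM, with an expected range of 500 nM to 1800 nM.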

Compound 4, half-maximal inhibitory concentration: 912 nM
Compound 4: middle estimate off by 1.0-fold (0.02 log units), on the high side, within the range that was stated.
By their numbers in this assay, from the lowest: compounds 2, 4, 1 and 3 (each within the scatter of the next).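

In this assay the step from fluoro to hydrogen on an aromatic carbon of a six-membered aromatic ring of carbon only, part of a fused or bridged system of two rings, can now be read directly (a 1.3-fold lower number from compound 3 to compound 4 (0.11 log units; within the scatter)), and the number does not leave the scatter. The two other single-place steps read the same way: the swap that brings in a fluoro group (a 1.0-fold higher number from compound 2 to compound 4 (0.01 log units; within the scatter)), and 2-methyl-1H-indol-3-yl in place of 4-fluoro-1H-indol-3-yl on a double-bonded ring carbon (a 1.0-fold lower number from compound 1 to compound 4 (0.00 log units; within the scatter)), so none of these small swaps separates compounds 1, 2, 3 and 4 on this read-out. No measurement in hand speaks to why these swaps leave the numbers so close together.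

From the compounds shown here alone, what stays open is whether anything at this aromatic carbon can move the number beyond the scatter, for example chloro, methoxy or an amine in place of the hydrogen of compound 4. The compounds shown also leave open how a group larger than methyl on the indole, such as ethyl or phenyl, would read in this assay.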